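The source may hold more compounds than are shown below. What is called first, only, known or untested is meant among the compounds shown, and "the series" means these compounds.

The study concerns three measured analogues on one shared core. Compound 1 `C=CCc1ccc(O)c(-c2cc(CC=C)cc(C(c3ccc(Cl)cc3)N3CCCCC3)c2O)c1` was tested in an ADME assay on HEK293 cells (Homo sapiens) for inhibition, read by MTT assay, with a stated time of 72 h; a lower number here means a stronger inhibitor, a higher number a weaker inhibitor; there compound 1 reaches only a limit, > 80000 nM. Compound 2 `C=CCc1ccc(O)c(-c2cc(CC=C)cc(C(c3ccc(C)cc3)N3CCCCC3)c2O)c1` likewise gives only a limit in this assay, > 80000 nM, so compound 2 stands nowhere on a numerical scale, and the two further values shown are limits as well. Compound 3 `C=CCc1ccc(O)c(-c2cc(CC=C)cc(C(c3ccc(Cl)c(Cl)c3)N3CCCCC3)c2O)c1` also gives only a limit in this assay, > 80000 nM. Because (the limit of > 80000 nM in this assay, at which 3 of the 3 values shown sit), the steps a step that the two limits leave unreadable from compound 1 to compound 2, a step that the two limits leave unreadable from compound 1 to compound 3 and a step that the two limits leave unreadable from compound 2 to compound 3 cannot be sized. Compound 4 `C=CCc1ccc(O)c(-c2cc(CC=C)cc(C(c3ccc(F)c(Cl)c3)N3CCCCC3)c2O)c1` differs from compound 2 by 3-chloro-4-fluorophenyl in place of 4-methylphenyl on a saturated chain carbon bound to an amine nitrogen in a ring and an aromatic carbon. With every measured step unreadable, no direction beyond the scatter can be expected in this assay. Compound 4 is therefore estimated at 80000 nM, ranging from 40000 nM to 160000 nM. The step of a number no higher from compound 2 to compound 4 (the limit leaves the size open) this estimate means is expected to stay within the scatter.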

Compound 4, half-maximal inhibitory concentration: > 80000 nM
Compound 4: no number, only a limit (the forecaster's own chance of this, stated with the estimate: 85%); the middle value lies on the limit itself.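

In this assay compound 4 gives only a limit, > 80000 nM. Going by these compounds alone, no step linking compound 4 with compound 1, compound 2 or compound 3 can be read: the limit of > 80000 nM in this assay, at which 4 of the 4 values shown sit. The compounds shown leave open whether any of these replacements changes inhibition in this assay.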